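Cytotoxicity of a Methylpiperazine Analogue Before Measurement

The source may report more compounds than this note shows. Statements on the series, on what has been measured and on what is new or still open speak of the compounds shown alone.

Compound 1 `CCCN(C)c1nc(Cc2c(F)cccc2F)cc(=O)[nH]1`: 85000 nM
Compound 2 `O=c1cc(Cc2c(F)cccc2F)nc(N2CCCCC2)[nH]1`: > 82000 nM
Compound 3 `CC1CCN(c2nc(Cc3c(F)cccc3F)cc(=O)[nH]2)CC1`: > 78000 nM

All three were tested in an ADME assay on MT4 cells (Homo sapiens) for cytotoxicity, read by MTT assay, with a stated time of 4 days; a lower number here means that less compound is tolerated, a higher number that more compound is tolerated. For the measured compounds named here, compound 1 gives 85000 nM, the only plain number among the three. For compound 2 the result is a limit of the assay, > 82000 nM. For compound 3 the result is likewise a limit, > 78000 nM. The step that the limit leaves unreadable from compound 1 to compound 2 and the step that the limit leaves unreadable from compound 1 to compound 3 therefore cannot be sized; the number for compound 1 sits close to the limit of > 78000 nM in this assay, at which 1 of the 3 values shown sits, and to the limit of > 82000 nM in this assay, at which 1 of the 3 values shown sits, so nothing beyond the scatter can be read from either step.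

Compound 4 `CN1CCN(c2nc(Cc3c(F)cccc3F)cc(=O)[nH]2)CC1` has not been measured. It differs from compound 1 by 4-methylpiperazin-1-yl in place of methyl(propyl)amino on an aromatic carbon. The two measured steps from compound 1, exchanging methyl(propyl)amino for piperidin-1-yl or 4-methylpiperidin-1-yl, bear on this change but give no readable size. Compound 4 is therefore expected to stay near compound 1, with an expected step of a 1.1-fold lower number from compound 1 to compound 4 (0.03 log units; within the scatter). The estimate for compound 4 is 80000 nM, with a range from 40000 nM to 160000 nM.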

Compound 4, half-maximal cytotoxic concentration: > 78000 nM
Compound 4: no number, only a limit; the forecaster's own chance of this, stated with the estimate: 60%; the middle value lies beyond the limit too.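

In this assay compound 4 gives only a limit, > 78000 nM, so its steps from compound 1, compound 2 and compound 3 cannot be read. The compounds shown leave open what concentration compound 2, compound 3 and compound 4 would actually reach, and so whether 4-methylpiperazin-1-yl and methyl(propyl)amino differ here at all.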